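A Larger Sulfur-Linked Side Chain in a Neprilysin Inhibitor

The source may hold more compounds than are shown below. What is called first, only, known or untested is meant among the compounds shown, and "the series" means these compounds.

Of the compounds shown here, two sharing the same mercaptomethyl-bearing core have been measured so far. Compound 1 `O=C(N[C@H](CSCc1ccccc1)C(=O)O)[C@H](CS)Cc1ccccc1` carries an acid and a benzylsulfanyl group on its right-hand portion, and in an assay on isolated protein for inhibition of Neprilysin (Oryctolagus cuniculus) (a lower number here means a stronger inhibitor, a higher number a weaker inhibitor), compound 1 gives 32 nM. Compound 2 `CSCC[C@@H](NC(=O)[C@H](CS)Cc1ccccc1)C(N)=O` instead ends in a primary amide and carries a (methylsulfanyl)methyl chain, and in this assay compound 2 gives 94 nM. Of the two numbers, compound 2 has the higher one, and the gap to compound 1 lies beyond the usual scatter of this assay.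

Compound 3 `Cc1ccc(CSC[C@@H](NC(=O)[C@H](CS)Cc2ccccc2)C(N)=O)cc1` is made from compound 2 by one change: (4-methylbenzyl)sulfanyl in place of (methylsulfanyl)methyl on a saturated chain carbon, two bonds along the chain from an amide-type nitrogen and a carbonyl carbon. For the measured compounds named here, no measured pair in this small set follows exactly that step, so its size has to be guessed. Because compound 1 gives 32 nM with a closely related benzylsulfanyl chain, the step from compound 2 to compound 3 is expected to lower the number, estimated at a 2.4-fold lower number from compound 2 to compound 3 (0.37 log units; beyond the scatter). Compound 3 is therefore expected to show about 40 nM, with a range from 12 nM to 130 nM.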

Compound 3, half-maximal inhibitory concentration: > 300 nM
Compound 3 was reported as a limit; the forecaster's own chance of this, stated with the estimate: 2%; middle value at least 7.5-fold (0.87 log units) from the limit.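

At this position, on a saturated chain carbon two bonds along the chain from an amide-type nitrogen and a carbonyl carbon, replacing (methylsulfanyl)methyl with the larger (4-methylbenzyl)sulfanyl gives an at least 3.1-fold higher number from compound 2 to compound 3 (0.50 log units; beyond the scatter) in this assay. Compound 3 is reported only as a limit, > 300 nM, and not as an exact number: the limit of > 300 nM in this assay, at which 1 of the 3 values shown sits. For the compounds shown here, this is the first measured step at this position, and it shows that on a compound ending in a primary amide, a group with one six-membered aromatic ring can weaken inhibition rather than strengthen it, though the full size of the loss stays unread.

Compound 1 differs from compound 3 in more than one place, so the two cannot be compared directly, and the separate contributions of the acid, the ring and the extra methyl remain unsettled. An ethylsulfanyl chain or a cyclohexylmethylsulfanyl group, which has a ring that is not aromatic, placed on the same primary amide would help show whether the higher number goes with the size of the group or with the aromatic ring.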